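Replacing trifluoromethyl on the distal ring of compound 2

A few compounds are considered here, and "the series" means these few. Any claim that something is new, unique, unknown or untested is made for them only; others in the source may bear on it.

Measured so far:
compound 1 `N[C@@H](CC1CCCCC1)CN(C(=O)[C@@H]1C[C@H]1c1ccccc1)c1ccc(-c2ccccc2)cc1` — 1.7 nM
compound 2 `CC[C@H](C)[C@H](N)CN(C(=O)[C@@H]1C[C@H]1c1ccccc1)c1ccc(-c2ccc(C(F)(F)F)cc2)cc1` — 340 nM

In a functional assay for agonist activity at G protein-coupled receptor 88 (Homo sapiens), read by HTRF and cAMP accumulation (on this read-out lower numbers stand for an effect already at smaller amounts and higher numbers for an effect only at larger amounts of compound), compound 1 gives 1.7 nM. In this assay compound 2 gives 340 nM, the highest of the two numbers, far beyond the scatter from compound 1; the two compounds differ in more than one place, so no single change is separated out. Compound 3 `CC[C@H](C)[C@H](N)CN(C(=O)[C@@H]1C[C@H]1c1ccccc1)c1ccc(-c2ccc(COC(C)(C)C)cc2)cc1` carries the change ((tert-butoxy)methyl in place of trifluoromethyl on an aromatic carbon). Among the compounds with values here, no comparable step between measured compounds exists, so the expectation rests on compound 2 alone. The estimated step of a 1.4-fold lower number from compound 2 to compound 3 (0.13 log units; within the scatter) is small, within or only just beyond the scatter. Compound 3 is expected to give 250 nM, between 50 nM and 1500 nM.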

Compound 3, half-maximal effective concentration: 280 nM
For compound 3 the middle estimate is 1.1-fold (0.05 log units) below the measured one; low and high end bracket the measured number.
By their numbers in this assay, from the lowest: compound 1; then compounds 3 and 2 (each within the scatter of the next).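

In this assay, putting (tert-butoxy)methyl in place of trifluoromethyl on this aromatic carbon gives a 1.2-fold lower number from compound 2 to compound 3 (0.08 log units; within the scatter). The position thus takes a larger group that carries a hydrogen-bond acceptor, where the leaving group has none, with no change in the read-out beyond the scatter. No available evidence explains why the two groups read alike. The compounds shown leave open whether an amine or a carboxylic acid on this carbon would read the same. They also leave open how a hydrogen atom there would compare.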